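A few compounds are considered here, and "the series" means these few. Any claim that something is new, unique, unknown or untested is made for them only; others in the source may bear on it.

Of the compounds shown here, three sharing one core have been measured in an assay on isolated protein for binding affinity to Adrenergic receptor alpha-1 (Rattus norvegicus), read by radioligand binding; a lower number here means a stronger inhibitor, a higher number a weaker inhibitor. Compound 1 `O=C1C2CCCN2C(=O)N1CN1CCN(c2ccccc2)CC1` carries an unsubstituted phenyl on the ring nitrogen and gives 1000 nM. Compound 2 `COc1ccccc1N1CCN(CN2C(=O)C3CCCN3C2=O)CC1` carries a 2-methoxyphenyl there and gives 500 nM. Compound 3 `O=C1C2CCCN2C(=O)N1CN1CCN(c2cccc(Cl)c2)CC1` carries a 3-chlorophenyl and gives 292 nM, the lowest of the three numbers, although its gap to compound 2 stays within the scatter. The step of a 3.4-fold lower number from compound 1 to compound 3 (0.53 log units; beyond the scatter) is the only one beyond the scatter; the steps of a 2.0-fold lower number from compound 1 to compound 2 (0.30 log units; within the scatter) and a 1.7-fold lower number from compound 2 to compound 3 (0.23 log units; within the scatter) both stay within it.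

Compound 4 `O=C1C2CCCN2C(=O)N1CN1CCN(c2ccc(F)cc2)CC1` has not yet been measured. Its change from compound 3 is 4-fluorophenyl in place of 3-chlorophenyl on an amine nitrogen in a ring. Among the measured compounds shown here, the steps that bear on this are the chloro step from compound 1 to compound 3, which was modest, and the methoxy step from compound 1 to compound 2, which stayed within the scatter. For the measured compounds named here, no measured compound carries fluorine, and none carries a group at this place on the phenyl, so the direction rests on the plain phenyl of compound 1 as the nearer reference. Because a 3.4-fold lower number from compound 1 to compound 3 (0.53 log units; beyond the scatter) was only modest and is being undone, the expected step is a 2.1-fold higher number from compound 3 to compound 4 (0.31 log units; beyond the scatter), a rise in number back toward compound 1. Compound 4 is therefore estimated at 600 nM, within a range from 250 nM to 1500 nM.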

Compound 4, inhibition constant: > 1000 nM
Compound 4: a limit, no number; the forecaster's own chance of this, stated with the estimate: 5%; middle value at least 1.6-fold (0.22 log units) away from the limit.
By their numbers in this assay, from the lowest: compounds 3, 2 and 1 (each within the scatter of the next, the first and the last beyond it).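

In this assay compound 4 gives > 1000 nM, which is a limit of the assay and not a number, and this limit marks how far the result can be read: the limit of > 1000 nM in this assay, at which 1 of the 4 values shown sits. Placing 4-fluorophenyl in place of 3-chlorophenyl on the amine nitrogen in a ring gives an at least 3.4-fold higher number from compound 3 to compound 4 (0.53 log units; beyond the scatter), so a halogen on the phenyl does not by itself bring a lower number: compound 3 has a lower number than the plain phenyl of compound 1, while compound 4 does not. Against the 2-methoxyphenyl, the change gives an at least 2.0-fold higher number from compound 2 to compound 4 (0.30 log units; that floor lies within the scatter), a floor that lies within the scatter and so does not separate the two compounds, and the fluoro step gives a number no lower from compound 1 to compound 4 (the limit leaves the size open).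

Going by these compounds, the 3-chlorophenyl and the 4-fluorophenyl differ in both the halogen and its place on the phenyl, so it stays open which of the two matters here. A 4-chlorophenyl or a 3-fluorophenyl on the same core would separate them.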